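Ethoxy in place of methyl: compound 2 to compound 3

The compounds below may be only part of what the source reports. "The series", "measured", "known", "first", "only" and "open" are said of these compounds alone.

Among the compounds with values here, in a functional assay on HeLa cells (Homo sapiens) for antiproliferative activity, with a stated time of 48 h (on this read-out higher numbers stand for weaker inhibition and lower numbers for stronger inhibition), compound 2 `C=C(Br)C(=O)Nc1ccc(/C=C/C(=O)c2ccc(C)cc2)cc1` gives 2100 nM and compound 1 `C=C(Br)C(=O)Nc1ccc(/C=C/C(=O)c2ccc(F)cc2)cc1` gives 1400 nM as the only two numbers so far. Within the data shown here, the sole measured step is a 1.5-fold higher number from compound 1 to compound 2 (0.18 log units; within the scatter) with methyl in place of fluoro at the same place, so compound 2 is not separated from compound 1. Compound 3 `C=C(Br)C(=O)Nc1ccc(/C=C/C(=O)c2ccc(OCC)cc2)cc1` differs from compound 2 by ethoxy in place of methyl on an aromatic carbon as ethoxy in place of methyl on an aromatic carbon, para to a large group. Among the measured compounds shown here, no measured compound carries ethoxy. With only a 1.5-fold higher number from compound 1 to compound 2 (0.18 log units; within the scatter) as a guide, no step beyond the scatter is expected in this assay here. The expected step is a 1.2-fold lower number from compound 2 to compound 3 (0.07 log units; within the scatter) on this estimate. For compound 3 the estimate is 1800 nM and a range from 700 nM to 4500 nM is expected.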

Compound 3, half-maximal inhibitory concentration: 750 nM
For compound 3 the middle estimate is 2.4-fold (0.38 log units) above the measured one; the measured number falls inside the stated range.
By their numbers in this assay, from the lowest: compounds 3, 1 and 2 (each within the scatter of the next, the first and the last beyond it).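

In this assay this position now gives a step beyond the scatter, modest in size, for ethoxy in place of methyl (a 2.8-fold lower number from compound 2 to compound 3 (0.45 log units; beyond the scatter)), which the earlier pair, methyl and fluoro, did not show. Ethoxy in place of fluoro stays within the scatter (a 1.9-fold lower number from compound 1 to compound 3 (0.27 log units; within the scatter)), so ethoxy is separated from methyl only. No measurement shown accounts for the step.

Open, on these data alone, is whether the oxygen or the chain matters, which methoxy at the same place would help to separate. Also open, as far as these compounds go, is how a longer chain such as propoxy, or an amine, would read here.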